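Acetylating the hydroxyl of a vanillylamide channel agonist

A few compounds are considered here, and "the series" means these few. Any claim that something is new, unique, unknown or untested is made for them only; others in the source may bear on it.

Compound 1: `COc1cc(CNC(=O)/C=C(\C)CCC[C@H](C)CCC[C@H](C)CCCC(C)C)ccc1O`, 2 nM
Compound 2: `CCCCCC[C@@H](O)C/C=C\CCCCCCCC(=O)NCc1ccc(O)c(OC)c1`, 3.16 nM

Of the compounds shown here, two have been measured in a functional assay on HEK293 cells with transient receptor potential cation channel subfamily V member 1 (Homo sapiens) as the target; on this read-out higher numbers stand for an effect only at larger amounts of compound and lower numbers for an effect already at smaller amounts. Compound 1 gives 2 nM and compound 2 gives 3.16 nM. Compound 2 has the higher of the two numbers, but its gap to compound 1 is within the usual scatter of this kind of measurement, so the two cannot be told apart on these data.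

Compound 3 is `CCCCCC[C@H](C/C=C\CCCCCCCC(=O)NCc1ccc(O)c(OC)c1)OC(C)=O`. It is derived from compound 2 by a single change: acetyl in place of hydrogen on an oxygen on a saturated carbon. Put more simply, the hydroxy group on the chain becomes an acetoxy group, so 1-hydroxyheptyl turns into 1-acetoxyheptyl, and the shared core with its amide and the long unsaturated chain stays the same.

Going by the values given here, no measured pair shows what this change does. With the hydrogen-bond donor of the hydroxyl removed and a larger group in its place, a modest shift toward a higher number in this assay seems plausible, but one that may well stay within the scatter. Compound 3 is therefore expected to give about 6 nM, with a likely range from 1.5 nM to 30 nM. This estimate corresponds to an expected step of a 1.9-fold higher number from compound 2 to compound 3 (0.28 log units; within the scatter).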

Compound 3, half-maximal effective concentration: 0.398 nM
The estimate for compound 3 lay 15-fold (1.18 log units) above the measured number; measured number outside the range, below it.
By their numbers in this assay, from the lowest: compound 3; then compounds 1 and 2 (each within the scatter of the next).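

Turning the hydroxy group into an acetoxy group on this chain gives a 7.9-fold lower number from compound 2 to compound 3 (0.90 log units; beyond the scatter) in this assay, a step beyond the scatter. A lower number means an effect at smaller amounts of compound, so this position on the chain accepts the larger acetyl group, and the hydrogen of the hydroxyl is not required for a low number here. Until now, no measured pair showed what a change at this oxygen does, and this one shows that it can move the number clearly, not just within the scatter, though nothing available explains why the number falls.

Going by these compounds, what remains open is how far this gain belongs to acetyl itself: a propionyl or benzoyl group on the same oxygen would show whether a longer or bulkier ester keeps it, and a methyl ether would show whether an ester is needed at all. An amine in place of the acetoxy group, or a carboxylic acid at this place on the chain, would test the position further, and the compounds shown say nothing about either.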